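The source may hold more compounds than are shown below. What is called first, only, known or untested is meant among the compounds shown, and "the series" means these compounds.

The measured compounds in this study:

compound 1, `O=C1C=CCC/C1=C\C(Br)=C\c1ccccc1`, > 10000 nM
compound 2, `Cc1ccc(/C=C/C=C2\CCC=CC2=O)cc1`, 5800 nM
compound 3, `O=C1C=CCC/C1=C\C=C\c1ccc(Cl)cc1`, 3200 nM

All three share one core and differ in the group on the benzene ring at the end of the diene chain. In a functional assay on Bel7402/5-FU cells (Homo sapiens) for cytotoxicity, read by MTT assay, with a stated time of 72 h (on this read-out higher numbers stand for weaker inhibition and lower numbers for stronger inhibition), compound 1 gives only a limit, (the limit of > 10000 nM in this assay, at which 1 of the 3 values shown sits), and not a number. Compound 2, carrying a methyl on that ring, gives 5800 nM in this assay. Compound 3 gives 3200 nM in this assay; its nearest neighbour among the numbers is compound 2, and the step of a 1.8-fold lower number from compound 2 to compound 3 (0.26 log units; within the scatter) lies within the scatter, so the two stand together rather than apart.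

The next compound is compound 4, `CC(=O)Oc1ccc(/C=C/C=C2\CCC=CC2=O)cc1`. Compared with compound 3 the change is acetoxy in place of chloro on an aromatic carbon. Going by the values given here, the only measured step that bears on a change at this position is the one from compound 2 to compound 3, and it stayed within the scatter; it does not involve acetoxy, so it speaks only indirectly. No step beyond the scatter is therefore expected, and the expected step is a 1.4-fold higher number from compound 3 to compound 4 (0.15 log units; within the scatter). For compound 4 the estimate in this assay is 4500 nM, with a range from 1500 nM to 13000 nM.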

Compound 4, half-maximal inhibitory concentration: 4100 nM
The estimate for compound 4 lay 1.1-fold (0.04 log units) above the measured number, and the stated range covers the measured number.
By their numbers in this assay, from the lowest: compounds 3, 4 and 2 (each within the scatter of the next). At a limit, above all of these: compound 1.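

In this assay, acetoxy, with four heavy atoms and two hydrogen-bond acceptors, takes the place of the single chlorine on an aromatic carbon para to a large group and gives a 1.3-fold higher number from compound 3 to compound 4 (0.11 log units; within the scatter) and, in place of methyl, a 1.4-fold lower number from compound 2 to compound 4 (0.15 log units; within the scatter) on that same carbon. The earlier compounds shown here compared only chloro with methyl; compounds 2, 3 and 4 now show that this position also accepts a larger group carrying hydrogen-bond acceptors without any step leaving the scatter, so the three stand together and no order can be drawn among them. Nothing available bears on why these three substituents stand together.

Whether an amine, a carboxylic acid or a longer chain at this position would stay with these three or produce the first step beyond the scatter remains open, since none of the steps shown at this position separates two compounds. Compound 1 gives only a limit of the assay, > 10000 nM and not a number, so steps to it cannot be read.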